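Trading a fluoroindanyl for a trifluoromethylbenzyl on a sulfonamide

A few compounds are considered here, and "the series" means these few. Any claim that something is new, unique, unknown or untested is made for them only; others in the source may bear on it.

Compound 1 `CC(C)CN(C1CCc2ccc(F)cc21)S(=O)(=O)c1ccc2c(c1)C(=O)CC(C1CCOCC1)O2` is measured in a physicochemical assay for lipophilicity, at pH 7.4 (a higher number here means a more lipophilic compound, a lower number a more polar compound), at 4.03. Among the three compounds measured, compound 1 stands second highest: compound 2 `CCc1ccc(N(CC(C)C)S(=O)(=O)c2ccc3c(c2)C(=O)CC(C2CCN(C(=O)C4CCCC4)CC2)O3)cc1` gives 5.13 in this assay, and compound 3 `CCc1ccc(NS(=O)(=O)c2ccc3c(c2)C(=O)CC(C2CCOCC2)O3)cc1` gives 2.67, both gaps lying beyond the usual scatter. Compound 4 `CC(C)CN(Cc1ccccc1C(F)(F)F)S(=O)(=O)c1ccc2c(c1)C(=O)CC(C1CCOCC1)O2` is not yet measured. It differs from compound 1 in one place: 2-(trifluoromethyl)benzyl in place of 6-fluoro-2,3-dihydro-1H-inden-1-yl on a sulfonamide nitrogen. Going by the values given here, no pair of measured compounds shows this change on its own, so the expectation rests on the change itself. The step from compound 1 to compound 4 is expected to be upward and modest, at a number 0.37 log units higher from compound 1 to compound 4 (beyond the scatter). Compound 4 is therefore estimated at 4.4 in this assay, with a likely range from 3.9 to 4.9.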

Compound 4, distribution coefficient: 4.32
Compound 4: middle estimate off by 0.08 log units, on the high side; low and high end bracket the measured number.
By their numbers in this assay, from the lowest: compound 3; then compounds 1 and 4 (each within the scatter of the next); then compound 2.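

In this assay, a step of a number 0.29 log units higher from compound 1 to compound 4 (within the scatter) comes with 2-(trifluoromethyl)benzyl in place of 6-fluoro-2,3-dihydro-1H-inden-1-yl on the sulfonamide nitrogen. Going by these compounds alone, this is the first reading of this change on its own, and it shows that a group with two rings and a group with one ring can be exchanged at this position with no difference beyond the scatter. No measurement at hand accounts for this result. Still open, on these data alone, is how a benzyl group carrying an amine or a carboxylic acid would read here, and whether this exchange gives the same step on a core carrying other groups.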